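The source may report more compounds than this note shows. Statements on the series, on what has been measured and on what is new or still open speak of the compounds shown alone.

Three compounds share one core and differ only in the aromatic group attached to it. Going by the values given here, compound 2 `CSc1cccc(Nc2nc(-c3cccc(Cl)c3)cs2)c1` carries a 3-chlorophenyl group and is one of only two compounds that gave a number at all in an assay on CFBE41o cells with Cystic fibrosis transmembrane conductance regulator variant F508del (Homo sapiens) as the target, with a stated time of 24 h (a lower number here means that less compound is needed, a higher number that more compound is needed for the effect), where compound 2 gives 5300 nM. Compound 3 `CSc1cccc(Nc2nc(-c3cccs3)cs2)c1` carries a thiophen-2-yl group instead, and in this assay compound 3 gives 8500 nM; the step of a 1.6-fold higher number from compound 2 to compound 3 (0.21 log units; within the scatter) stays within the scatter, so the two cannot be ranked. Compound 1 `CSc1cccc(Nc2nc(-c3ccc(F)cc3)cs2)c1` carries a 4-fluorophenyl group, and in this assay compound 1 is reported as "not active" (no number reported).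

Compound 4 `CSc1cccc(Nc2nc(-c3ccc(Cl)c(Cl)c3)cs2)c1` differs from compound 2 by chloro in place of hydrogen on an aromatic carbon. Among the compounds with values here, no measured step adds a group in this way; the step from compound 2 to compound 3 swaps the whole ring and is within the scatter, and compound 1 gives no number. The expectation for compound 4 is therefore a modest step, a 1.8-fold lower number from compound 2 to compound 4 (0.25 log units; within the scatter), towards a smaller number, with wide uncertainty. In this assay compound 4 is estimated at 3000 nM, within a range from 800 nM to 15000 nM.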

Compound 4, half-maximal effective concentration: 14000 nM
Compound 4: the middle estimate sits 4.7-fold (0.67 log units) below what was measured; low and high end bracket the measured number.
By their numbers in this assay, from the lowest: compounds 2, 3 and 4 (each within the scatter of the next, the first and the last beyond it).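

Placing chloro on the carbon ortho to the chloro group of compound 2 and para to a large group gives a step that can be read: in this assay there is a 2.6-fold higher number from compound 2 to compound 4 (0.42 log units; beyond the scatter), so more compound is needed. This carbon therefore does not tolerate every change without effect, although the step is modest and involves a single added heavy atom. Going by these compounds alone, the earlier compounds could not show this, since their only numerical step swapped the whole ring and stayed within the scatter. Nothing measured here accounts for the higher number.

Chloro is the only group shown at this carbon, so it remains open whether a methoxy group, a nitrile or an amine there would give a similar number. Also open, on these data alone, is whether the same chloro would have a similar effect on a ring lacking the first chloro group.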